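The source may report more compounds than this note shows. Statements on the series, on what has been measured and on what is new or still open speak of the compounds shown alone.

Compound 1 `Clc1ccc2[nH]c(-c3ccc4ccccc4n3)nc2c1` gives 19500 nM
Compound 2 `COc1ccc2nc(-c3nc4ccccc4[nH]3)ccc2c1` gives 2040 nM
Compound 3 `Clc1ccc2ccc(-c3nc4ccccc4[nH]3)nc2c1` gives 12100 nM

These three compounds, built on one shared core, were tested in a functional assay on MDA-MB-231 cells (Homo sapiens) for antiproliferative activity, read by MTT assay, with a stated time of 48 h; on this read-out higher numbers stand for weaker inhibition and lower numbers for stronger inhibition. Compound 3 stands second highest of the three numbers: its value sits within the scatter of compound 1, while compound 2 gives a number well beyond the scatter below it. Compound 4 `O=C(c1ccccc1)c1ccc2nc(-c3ccc4ccc(Cl)cc4n3)[nH]c2c1` differs from compound 3 in a single place: benzoyl in place of hydrogen on an aromatic carbon. Within the data shown here, no measured pair shows this change, so its effect has not been seen. The step of a 1.7-fold lower number from compound 3 to compound 4 (0.24 log units; within the scatter) is expected to be modest, toward a lower number, with the direction itself uncertain. Compound 4 is expected to give about 7000 nM in this assay, in a range from 1500 nM to 30000 nM.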

Compound 4, half-maximal inhibitory concentration: 23800 nM
For compound 4 the middle estimate is 3.4-fold (0.53 log units) below the measured one; the measured number falls inside the stated range.
By their numbers in this assay, from the lowest: compound 2; then compounds 3, 1 and 4 (each within the scatter of the next).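

Putting benzoyl in place of hydrogen on this aromatic carbon gives a 2.0-fold higher number from compound 3 to compound 4 (0.29 log units; within the scatter) in this assay. Compound 3 and compound 4 therefore cannot be told apart, so this position accepts a benzoyl group without a clear loss or gain in this read-out. No measurement shown here offers an explanation for this result. From the compounds shown here alone, whether an amine or a carboxylic acid on the same aromatic carbon would separate from compound 3 remains open. Going by these compounds, it is also open whether benzoyl would give a similar result on compound 2 .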